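Urea analogues in a plant whole-organism assay

This account rests on a few compounds, and the source may have more. Where it says the series, first, only, none or still open, it means among the compounds named here.

Compounds measured so far:
compound 1 `C[C@@H](NC(=O)Nc1ccc(C(C)(C)C)cc1)c1ccccc1` — 100%
compound 2 `C[C@H](NC(=O)Nc1ccc(C(C)(C)C)cc1)c1ccccc1` — 100%
compound 3 `CCCCCc1ccc(NC(=O)N[C@@H](C)c2ccccc2)cc1` — 98%

In an ADME assay on the whole organism with Oryza sativa as the target, tested at 0.1 uM (a lower number here means a stronger effect, a higher number a weaker effect of the compound at the concentration tested), compound 1 gives 100%, level with compound 2 and together the highest of the three numbers; the step to compound 3 is a number 2 percentage points lower from compound 2 to compound 3 (within the scatter), and no change at the digits printed from compound 1 to compound 2 (within the scatter) rests on (the fact that compounds 1 and 2 differ only in the configuration as drawn). Compound 4 `CCOC(=O)c1ccc(NC(=O)N[C@H](C)c2ccccc2)cc1` differs from compound 1 by ethoxycarbonyl in place of tert-butyl on an aromatic carbon. Among the measured compounds shown here, neither measured step exchanges an alkyl group for an ethoxycarbonyl, so no step bears directly on this change; both stayed within the scatter. Compound 4 is therefore expected to show no step beyond the scatter, a number 3 percentage points lower from compound 1 to compound 4 (within the scatter). The estimate for compound 4 is 97%, between 80% and 100%.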

Compound 4, a percentage reported as activity, at one concentration (the size of the read-out at that concentration, not a potency): 101%
Compound 4: middle estimate off by 4 percentage points, on the low side, and the stated range ends below it.
By their numbers in this assay, from the lowest: compounds 3, 1, 2 and 4 (each within the scatter of the next).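

With ethoxycarbonyl in place of tert-butyl on this aromatic carbon, this assay shows a number 1 percentage points higher from compound 1 to compound 4 (within the scatter) and so no real change. The position therefore takes more than the alkyl groups seen so far: a group with oxygen atoms and hydrogen-bond acceptors leaves the number where it was. Nothing available explains this result. On these data alone, whether an amine or a carboxylic acid at this position would move the number beyond the scatter remains open.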